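Benzyl thioether series: nitrophenyl variant of the shared core

This account rests on a few compounds, and the source may have more. Where it says the series, first, only, none or still open, it means among the compounds named here.

Compound 1 `Clc1cccc(CSc2nnc(-c3ccncc3)n2-c2ccccc2)c1` in a functional assay on MCF7 cells (Homo sapiens) for inhibition, read by MTT assay, with a stated time of 48 h (a lower number here means a stronger inhibitor, a higher number a weaker inhibitor), gives 10500 nM. Compound 2 `Fc1cccc(F)c1CSc1nnc(-c2ccncc2)n1-c1ccccc1` in this assay reaches only a limit, > 50000 nM. Among the measured compounds shown here, the single measured comparison, an at least 4.7-fold higher number from compound 1 to compound 2 (0.67 log units; beyond the scatter), leaves compound 2 standing at the limit of > 50000 nM in this assay, at which 1 of the 2 values shown sits, so no number is known for it. Compound 3 `O=[N+]([O-])c1ccc(CSc2nnc(-c3ccncc3)n2-c2ccccc2)cc1` differs from compound 2 by 4-nitrophenyl in place of 2,6-difluorophenyl on a saturated chain carbon bound to a sulfur. With compound 2 known only as a limit, the step to compound 3 can be bounded, not sized; the value of compound 1 is the nearest anchor. Compound 3 is expected near 15000 nM, between 4000 nM and 60000 nM. This estimate implies an at least 3.3-fold lower number from compound 2 to compound 3 (0.52 log units; beyond the scatter).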

Compound 3, half-maximal inhibitory concentration: 22800 nM
Estimate against measurement, compound 3: 1.5-fold (0.18 log units) below; the measured number falls inside the stated range.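

In this assay, the position on a saturated chain carbon bound to a sulfur gives a measured number with 4-nitrophenyl, which replaces a limit with a value: an at least 2.1-fold lower number from compound 2 to compound 3 (0.34 log units; beyond the scatter). Against 3-chlorophenyl the same group loses ground, with a 2.2-fold higher number from compound 1 to compound 3 (0.34 log units; beyond the scatter), so compound 1 keeps the lower number of the two measured values. Compound 2 remains a limit of the assay, not a number: the limit of > 50000 nM in this assay, at which 1 of the 3 values shown sits.

Going by these compounds, what an amine or a carboxylic acid on this phenyl ring would give in this assay stays open. So does the effect of a longer chain between the sulfur and the ring.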